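The source may hold more compounds than are shown below. What is called first, only, known or untested is meant among the compounds shown, and "the series" means these compounds.

Compound 1 `O=C(Nc1cc(C(F)(F)F)ccc1C(F)(F)F)c1ccc(Sc2ccc(O)cc2)cc1` and compound 2 `O=C(Nc1ccc(S(F)(F)(F)(F)F)cc1)c1ccc(Sc2ccc(O)cc2)cc1` both carry a (4-hydroxyphenyl)sulfanyl group on a shared core, and the difference between their two cores is not broken down here. In a functional assay on DU-145 cells (Homo sapiens) for antiproliferative activity, read by fluorescence and propidium iodide staining, with a stated time of 96 h (a higher number here means a weaker inhibitor, a lower number a stronger inhibitor), compound 1 gives 16600 nM, while compound 2 gives 6760 nM, the lowest of the three numbers measured, beyond the scatter from both others. Compound 3 `O=C(Nc1cc(C(F)(F)F)ccc1C(F)(F)F)c1ccc(S(=O)(=O)c2ccc(O)cc2)cc1` differs from compound 1 by (4-hydroxyphenyl)sulfonyl in place of (4-hydroxyphenyl)sulfanyl on an aromatic carbon; in this assay compound 3 gives 27800 nM, so that a 1.7-fold higher number from compound 1 to compound 3 (0.22 log units; within the scatter). Compound 4 `O=C(Nc1ccc(S(F)(F)(F)(F)F)cc1)c1ccc(S(=O)(=O)c2ccc(O)cc2)cc1` stands to compound 2 exactly as compound 3 stands to compound 1, differing by (4-hydroxyphenyl)sulfonyl in place of (4-hydroxyphenyl)sulfanyl on an aromatic carbon at the same place; this change occurs twice among the compounds shown. Among the compounds with values here, the expected step here is a 1.7-fold higher number from compound 2 to compound 4 (0.23 log units; within the scatter), resting on the single measured instance a 1.7-fold higher number from compound 1 to compound 3 (0.22 log units; within the scatter), which is within the scatter. Compound 4 is therefore estimated at 11500 nM in this assay, with a likely range from 5000 nM to 26000 nM.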

Compound 4, half-maximal inhibitory concentration: 10900 nM
Compound 4: the middle estimate sits 1.1-fold (0.02 log units) above what was measured; measured number inside the range.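

In this assay, putting (4-hydroxyphenyl)sulfonyl in place of (4-hydroxyphenyl)sulfanyl gives a 1.6-fold higher number from compound 2 to compound 4 (0.21 log units; within the scatter). Set beside the earlier step, the same replacement behaves alike on both cores, with no difference that can be told apart from noise: the same change on two cores in this assay, a 1.7-fold higher number (0.22 log units; within the scatter) from compound 1 to compound 3 and a 1.6-fold higher number (0.21 log units; within the scatter) from compound 2 to compound 4, 1.0-fold (0.02 log units) apart, within the scatter of two such steps. This shows only that the replacement transfers consistently between these two cores; since neither step stands clear of the scatter, it does not show that the replacement moves the antiproliferative reading at all, and two cores give no basis for a rule across the wider series.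

The compounds shown leave open how the reading would respond if an ether oxygen or a methylene took the place of the sulfur link, or if a methoxy group or an amine took the place of the hydroxyl. They also leave open whether the replacement would behave the same way on a core carrying a nitrile or a carboxylic acid.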